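The compounds below may be only part of what the source reports. "The series", "measured", "known", "first", "only" and "open" are said of these compounds alone.

Measured so far:
compound 1 `COc1ncc(-c2ccc3ncnc(NCCN4CCCCC4)c3c2)cc1C#N` — 2740 nM in a functional assay on MCF7 cells (Homo sapiens) for antiproliferative activity, read by MTT assay, with a stated time of 72 h; on this read-out higher numbers stand for weaker inhibition and lower numbers for stronger inhibition
compound 2 `COc1ccc(-c2ccc3ncnc(NCCN4CCCCC4)c3c2)cn1` — in this assay compound 2 gives 2420 nM

Compound 1 has the highest number of the two, with compound 2 nearest; the step of a 1.1-fold lower number from compound 1 to compound 2 (0.05 log units; within the scatter) is within the scatter. Compound 3 `CCN(CC)CCNc1ncnc2ccc(-c3cnc(OC)c(C#N)c3)cc12` differs from compound 1 by diethylamino in place of piperidin-1-yl on a saturated chain carbon, two bonds along the chain from a nitrogen on an aromatic ring. For the measured compounds named here, no measured step bears on this change; the only step known, hydrogen in place of cyano on an aromatic carbon, sits elsewhere and was within the scatter. Nothing here points to a step beyond the scatter, so compound 3 is expected near compound 1, at 3000 nM (range 1200 nM to 7500 nM), a step of a 1.1-fold higher number from compound 1 to compound 3 (0.04 log units; within the scatter) that is an estimate only.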

Compound 3, half-maximal inhibitory concentration: 3860 nM
For compound 3 the middle estimate is 1.3-fold (0.11 log units) below the measured one, within the range that was stated.
By their numbers in this assay, from the lowest: compounds 2, 1 and 3 (each within the scatter of the next).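

Diethylamino in place of piperidin-1-yl, on a saturated chain carbon, two bonds along the chain from a nitrogen on an aromatic ring, gives a 1.4-fold higher number from compound 1 to compound 3 (0.15 log units; within the scatter) in this assay and so leaves the number within the scatter. For the compounds shown here, on this one pair, the closed ring of piperidin-1-yl is not needed at this place to hold the number, and this is the first reading at the amine end of the chain. No measurement at hand offers an explanation for this result.

As far as these compounds go, whether a morpholine, a primary amine or a longer chain would hold the number at this place remains open. So does whether the same exchange reads alike with hydrogen in place of cyano.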